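A few compounds are considered here, and "the series" means these few. Any claim that something is new, unique, unknown or untested is made for them only; others in the source may bear on it.

Measured so far, in a functional assay on the whole organism (strain Albino Swiss CD1) with Mus musculus as the target, in the maximal electroshock model; on this read-out higher numbers stand for an effect only at larger amounts of compound and lower numbers for an effect already at smaller amounts:

Compound 1, `CC(C(=O)NCc1ccccc1Cl)N1C(=O)CCC1=O`, gives 74.5 mg/kg.
Compound 2, `CC(C(=O)NCc1ccc(Cl)cc1)N1C(=O)CCC1=O`, gives 91.8 mg/kg.
Compound 3, `CCC(C(=O)NCc1ccccc1)N1C(=O)CCC1=O`, gives 73.3 mg/kg.

These three share one core and differ only in the short chain on the carbon next to the amide and in whether a chloro group sits on the benzyl ring. On the numbers shown, compound 3 cannot be told apart from the other two: its gaps to compound 1 and to compound 2 both lie within the usual scatter of repeated measurements, so no ranking among the three can be claimed.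

Compound 4, `CCC(C(=O)NCc1cccc(Cl)c1)N1C(=O)CCC1=O`, has not yet been measured in this assay. It keeps the ethyl chain of compound 3 and adds one change: chloro in place of hydrogen on an aromatic carbon. Among the measured compounds shown here, no pair of measured compounds shows this exact change on its own. What the measured set does show is that compound 1 and compound 2, which carry a chloro group on a methyl-chain analogue, sit within the scatter of compound 3, which carries none. For the measured compounds named here, with that as the only guide, the expected step of a 1.1-fold higher number from compound 3 to compound 4 (0.04 log units; within the scatter) is none beyond the scatter. The estimated value for compound 4 is therefore 80 mg/kg, with a range from 45 mg/kg to 140 mg/kg.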

Compound 4, dose for half-maximal effect: 96.6 mg/kg
For compound 4 the middle estimate is 1.2-fold (0.08 log units) below the measured one; low and high end bracket the measured number.
By their numbers in this assay, from the lowest: compounds 3, 1, 2 and 4 (each within the scatter of the next).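

Among the compounds shown here, this is the first pair in the set that differs in one place only, so the chloro group can now be read on its own with the ethyl chain held fixed: in this assay, going from phenyl to 3-chlorophenyl gives a 1.3-fold higher number from compound 3 to compound 4 (0.12 log units; within the scatter) and nothing else changes. That step lies within the scatter, so replacing hydrogen with chloro at this place on the aromatic ring, meta to a large group, gives no difference that can be separated from what repeated measurements of one compound would show. Nothing measured here offers a reason for this result.

On these data alone, whether chloro at other places on this ring would also leave the number within the scatter stays open, as compound 1 and compound 2 carry their chloro groups with a methyl chain and so differ from compound 4 in more than one place. Also open, as far as these compounds go, is whether a different group at this same place, such as a methoxy group, an amine or a carboxylic acid, would move the number beyond the scatter.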